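This account rests on a few compounds, and the source may have more. Where it says the series, first, only, none or still open, it means among the compounds named here.

The measurements come from a functional assay on HEK293 cells for antagonist activity at Orexin receptor type 2 (Homo sapiens), read by FLIPR and calcium flux; on this read-out lower numbers stand for lower potency and higher numbers for higher potency (the scale is a negative logarithm). The three measured compounds are:

compound 1, `Cc1ccnc(NC[C@@H]2CC3(CC3)CN2C(=O)c2nc(C)sc2-c2ccccc2)n1`: 7
compound 2, `Cc1nc(C(=O)N2CCC3(CC3)C[C@H]2CNc2ccc(Cl)cn2)c(-c2ccccc2)s1`: a limit of the assay, < 5
compound 3, `Cc1ccc(-c2ncccn2)c(C(=O)N2CC3(CC3)C[C@H]2CNc2ccc(Cl)cn2)c1`: a limit of the assay, < 5

Going by the values given here, compound 1 holds the only actual number among the three; in this assay compound 1 gives 7. Among the compounds with values here, the other two entries are covered by the limit of < 5 in this assay, at which 2 of the 3 values shown sit, so they offer no number to set against compound 1, and no step between measured compounds can be drawn from this set.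

Compound 4, `Cc1cc(C)nc(NC[C@@H]2CC3(CC3)CN2C(=O)c2nc(C)sc2-c2ccccc2)n1`, is to be measured in this assay next. It differs from compound 1 in one place: methyl in place of hydrogen on an aromatic carbon. Within the data shown here, with no measured step to lean on, the expectation rests on that change alone, and the expected step of no change at the digits printed from compound 1 to compound 4 (within the scatter) is taken to stay within the usual scatter, in neither direction beyond it. Compound 4 is therefore estimated at 7, with a range from 6.3 to 7.7.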

Compound 4, negative logarithm of the antagonist equilibrium constant: 8.6
For compound 4 the middle estimate is 1.60 log units below the measured one, and the stated range ends below it.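

This position on the pyrimidine, an aromatic carbon next to the ring nitrogen, turns out to matter a great deal in this assay: methyl in place of hydrogen gives a number 1.60 log units higher from compound 1 to compound 4 (beyond the scatter). Going by these compounds alone, the earlier compounds offered no measured step, so this is the first sign that so small a change, one added carbon with no hydrogen-bond donor or acceptor and no net charge, can move the read-out well past the scatter. Nothing shown here accounts for the size of this step.

Going by these compounds, it remains open whether the rise belongs to methyl specifically or would also come with an ethyl group, a chlorine or a methoxy group at this carbon. A single step also cannot tell whether the same methyl would do as much on a different core.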